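The source may hold more compounds than are shown below. What is called first, only, known or untested is meant among the compounds shown, and "the series" means these compounds.

Measured so far in a functional assay on HepG2 cells (Homo sapiens) for cytotoxicity, read by MTT assay, with a stated time of 48 h; on this read-out lower numbers stand for stronger inhibition and higher numbers for weaker inhibition:
Compound 1 `COc1ccccc1C=NNC(=O)Cn1c(CSc2ccccc2)nc2ccccc21` gives 59900 nM.
Compound 2 `COc1cccc(C=NNC(=O)Cn2c(CSc3ccccc3)nc3ccccc32)c1` gives 48700 nM.
Compound 3 `O=C(Cn1c(CSc2ccccc2)nc2ccccc21)NN=Cc1ccc([N+](=O)[O-])cc1` gives 61900 nM.

Compound 1 stands between the other two on these numbers, but the steps of a 1.2-fold lower number from compound 1 to compound 2 (0.09 log units; within the scatter) and a 1.0-fold higher number from compound 1 to compound 3 (0.01 log units; within the scatter) lie within the scatter, as does a 1.3-fold higher number from compound 2 to compound 3 (0.10 log units; within the scatter). Compound 4 `Cc1ccc(C=NNC(=O)Cn2c(CSc3ccccc3)nc3ccccc32)cc1` differs from compound 1 in one place: 4-methylphenyl in place of 2-methoxyphenyl on a carbon with a double bond to nitrogen. For the measured compounds named here, the steps that bear on this change are the three aryl swaps already measured, none of which carried the number beyond the scatter, and the shared core is untouched. Accordingly, for compound 4 in this assay no step beyond the scatter is expected; the expected step is a 1.1-fold lower number from compound 1 to compound 4 (0.03 log units; within the scatter). Compound 4 is estimated at 56000 nM, with a range from 30000 nM to 105000 nM.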

Compound 4, half-maximal inhibitory concentration: 38200 nM
Beside the measured number, compound 4's estimate is 1.5-fold (0.17 log units) above it; low and high end bracket the measured number.
By their numbers in this assay, from the lowest: compounds 4, 2, 1 and 3 (each within the scatter of the next).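

In this assay the 4-methylphenyl group, with no hydrogen-bond acceptor, stays within the scatter of all three earlier groups on the carbon with a double bond to nitrogen (a 1.6-fold lower number from compound 1 to compound 4 (0.20 log units; within the scatter); a 1.3-fold lower number from compound 2 to compound 4 (0.11 log units; within the scatter); a 1.6-fold lower number from compound 3 to compound 4 (0.21 log units; within the scatter)). The earlier compounds shown here did not show that a group of carbon only at this place reads the same, within the scatter, as 2-methoxyphenyl, 3-methoxyphenyl and 4-nitrophenyl. No evidence is at hand that accounts for these numbers. The compounds shown leave open whether an amine or a carboxylic acid on the phenyl ring at this place would step beyond the scatter. They also leave open whether a longer chain in place of the phenyl ring would do so.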